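A few compounds are considered here, and "the series" means these few. Any claim that something is new, unique, unknown or untested is made for them only; others in the source may bear on it.

Measured compounds in an assay on HEK293 cells for inhibition of Lysophosphatidylserine lipase ABHD12 (Homo sapiens), read by scintillation counting, with stated times of 30 min and 5 min; on this read-out higher numbers stand for weaker inhibition and lower numbers for stronger inhibition:
compound 1, `Cc1c(-c2ccc(F)cc2)cc(C(=O)NC2CCCCCC2)c(=O)n1Cc1ccc(F)cc1`: 600 nM
compound 2, `COc1ccc(-c2cc(C(=O)NC3CCCCCC3)c(OCc3ccc(F)cc3)nc2C)cc1`: > 10000 nM, a limit of the assay
compound 3, `Cc1nc(OCc2ccc(F)cc2)c(C(=O)NC2CCCCCC2)cc1Br`: 2100 nM

Of the two numbers that are numbers, compound 1 holds the lower one; compound 3 gives 2100 nM, a higher number than compound 1 and a gap that lies beyond the usual scatter. Compound 2 sits at the limit of the assay, (the limit of > 10000 nM in this assay, at which 1 of the 3 values shown sits), so its value is a bound and not a number.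

Compound 4, `Cc1c(F)cc(C(=O)NC2CCCCCC2)c(=O)n1Cc1ccc(F)cc1`, is built from compound 1 by a single change: fluoro in place of 4-fluorophenyl on an aromatic carbon. Among the measured compounds shown here, one measured step bears on this kind of change, the replacement of an aryl group by a halogen at the same position of the shared core, seen as an at least 4.7-fold lower number from compound 2 to compound 3 (0.67 log units; beyond the scatter). Compound 2 and compound 3 carry a different core from compound 1, and compound 2 itself stands at a limit, so the size of that step is only a floor. Taken as a guide, it points toward a lower number in this assay for compound 4 than for compound 1, of modest size, expected as a 1.7-fold lower number from compound 1 to compound 4 (0.23 log units; within the scatter). Compound 4 is therefore estimated at 350 nM, with a likely range from 120 nM to 1200 nM.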

Compound 4, half-maximal inhibitory concentration: > 10000 nM
Compound 4 ended at the assay's limit; the forecaster's own chance of this, stated with the estimate: 5%; middle value at least 28-fold (1.45 log units) from the limit.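

In this assay, replacing 4-fluorophenyl with fluoro on this aromatic carbon, ortho to the methyl group and two atoms from the ring nitrogen, gives an at least 16-fold higher number from compound 1 to compound 4 (1.22 log units; beyond the scatter), which shows that on the core of compound 1 inhibition does not survive this exchange. Going by these compounds, compound 4 gives > 10000 nM, which is a limit of the assay and not a number, so the true size of the step remains unknown. The earlier step, an at least 4.7-fold lower number from compound 2 to compound 3 (0.67 log units; beyond the scatter), ran the opposite way on a different core, and nothing measured here gives a reason for the contrast.

The compounds shown leave open whether the loss on the core of compound 1 follows the removal of the aromatic ring or the arrival of fluoro, as only one small replacement is shown there. An unsubstituted phenyl, a bromo group, an amine or a short alkyl chain such as ethyl at this position would begin to separate these readings.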